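Coumarin-triazole dienones: naphthalene in place of methoxyphenyl

The source may hold more compounds than are shown below. What is called first, only, known or untested is meant among the compounds shown, and "the series" means these compounds.

Measured so far in a functional assay on COLO 205 cells (Homo sapiens) for inhibition, read by sulforhodamine B assay, with a stated time of 48 h, tested at 50 uM; on this read-out lower numbers stand for less inhibition of growth and higher numbers for more inhibition of growth at the one concentration tested:
compound 1 `COc1ccccc1/C=C/C(=O)/C=C/c1ccc(OCc2cn(CCOc3cc(=O)oc4ccccc34)nn2)c(OC)c1` gives 67%
compound 2 `COc1cc(/C=C/C(=O)/C=C/c2ccco2)ccc1OCc1cn(CCCCCOc2cc(=O)oc3ccccc23)nn1` gives 33%
compound 3 `COc1cc(/C=C/C(=O)/C=C/c2ccco2)ccc1OCc1cn(CCCOc2cc(=O)oc3ccccc23)nn1` gives 59%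

On these three numbers compound 1 stands highest. Compound 3 comes nearest, its number lying within the usual scatter of that of compound 1, so no order between the two can be read from this assay. Compound 2 lies furthest off, and its gap to compound 1 is beyond the scatter. Going by the values given here, no pair among the three differs in only one place, so no single step between measured compounds is known, and the spread between compound 2 and compound 3, which share the furan end, goes with a different chain length to the coumarin oxygen rather than with one exchange.

The next compound, compound 4 `COc1cc(/C=C/C(=O)/C=C/c2cccc3ccccc23)ccc1OCc1cn(CCOc2cc(=O)oc3ccccc23)nn1`, keeps the whole of compound 1 except one terminal group: naphthalen-1-yl in place of 2-methoxyphenyl on a double-bonded chain carbon bound to a double-bonded chain carbon. The two-carbon chain to the coumarin oxygen, which compound 1 carries, is kept. Among the compounds with values here, with no measured step to lean on, the change is expected to move this assay little, with the step from compound 1 to compound 4 estimated at a number 7 percentage points lower from compound 1 to compound 4 (within the scatter), within or near the scatter. For compound 4 the estimate in this assay is 60%, with a range from 40% to 78%.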

Compound 4, percent growth inhibition at one concentration: 85%
Beside the measured number, compound 4's estimate is 25 percentage points below it, outside the stated range (above it).
By their numbers in this assay, from the lowest: compound 2; then compounds 3 and 1 (each within the scatter of the next); then compound 4.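

Going by these compounds alone, compound 4 gives the first step that can be read at a single place: in this assay, naphthalen-1-yl in place of 2-methoxyphenyl on a double-bonded chain carbon bound to a double-bonded chain carbon gives a number 18 percentage points higher from compound 1 to compound 4 (beyond the scatter). With the rest of compound 1 kept, the terminal group at this place therefore moves growth inhibition at the one concentration tested, and the methoxy-bearing single ring is not required for a high number in this read-out. No measurement shown here accounts for the step.

The exchange alters two things at once, going from one six-membered aromatic ring of carbon only and one hydrogen-bond acceptor to two such rings and no hydrogen-bond acceptor, so this single step cannot separate the added ring from the lost oxygen. The compounds shown also leave open how a plain phenyl, naphthalen-2-yl or a phenyl carrying an amine or a carboxylic acid would read at this place, and whether the step would hold on a longer chain to the coumarin oxygen.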